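Adding trifluoromethyl to compound 3

The compounds below may be only part of what the source reports. "The series", "measured", "known", "first", "only" and "open" are said of these compounds alone.

In a functional assay on CWR22R cells (Homo sapiens) for antiproliferative activity, read by propidium iodide staining, with a stated time of 96 h (a lower number here means a stronger inhibitor, a higher number a weaker inhibitor), compound 3 `CC(O)(COc1ccc(C#N)cc1)C(=O)Nc1ccc(S(F)(F)(F)(F)F)cc1` gives 26100 nM. Compound 1 `CC(O)(CSc1ccc(F)cc1)C(=O)Nc1ccc(S(F)(F)(F)(F)F)cc1` gives 13500 nM, a gap of a 1.9-fold higher number from compound 1 to compound 3 (0.29 log units; within the scatter), so this step offers no guide here. Compound 2 `CC(O)(COc1ccccc1C(F)(F)F)C(=O)Nc1ccc(S(F)(F)(F)(F)F)cc1` gives 1400 nM.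

Compound 4 `CC(O)(COc1ccc(C#N)cc1C(F)(F)F)C(=O)Nc1ccc(S(F)(F)(F)(F)F)cc1` differs from compound 3 by trifluoromethyl in place of hydrogen on an aromatic carbon, ortho to a large group and meta to a cyano group.

The closest evidence is a 19-fold higher number from compound 2 to compound 3 (1.27 log units; beyond the scatter), a large step in which 4-cyanophenyl replaces 2-(trifluoromethyl)phenyl. Among the measured compounds shown here, that step changes two things at once, and no measured step adds trifluoromethyl alone. Only part of it should therefore carry over, and a clearly lower number is expected in this assay, a 6.5-fold lower number from compound 3 to compound 4 (0.81 log units; beyond the scatter). The estimate for compound 4 is 4000 nM, within a range of 1000 nM to 16000 nM.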

Compound 4, half-maximal inhibitory concentration: 13800 nM
The estimate for compound 4 lay 3.5-fold (0.54 log units) below the measured number; low and high end bracket the measured number.
By their numbers in this assay, from the lowest: compound 2; then compounds 1, 4 and 3 (each within the scatter of the next).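

In this assay trifluoromethyl in place of hydrogen on this aromatic carbon, ortho to a large group, leaves the two compounds within the scatter of each other (a 1.9-fold lower number from compound 3 to compound 4 (0.28 log units; within the scatter)). Cyano in place of hydrogen on an aromatic carbon gives a step beyond the scatter (a 9.9-fold higher number from compound 2 to compound 4 (0.99 log units; beyond the scatter)), so the large gap seen earlier goes with the cyano group rather than with trifluoromethyl. No measurement shown explains either result. Still open, on these data alone, is whether trifluoromethyl would matter if an amine or a carboxylic acid stood in place of the cyano group.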